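A few compounds are considered here, and "the series" means these few. Any claim that something is new, unique, unknown or untested is made for them only; others in the source may bear on it.

Among the compounds with values here, compound 2 `CC(=O)OC[C@H]1O[C@@H](n2cc(-c3cc(-c4ccc(C(C)(C)C)cc4)no3)c(=O)[nH]c2=O)C[C@@H]1OC(C)=O` gives 32.8% in a functional assay on NUGC-3 cells (Homo sapiens) for cytotoxicity, read by sulforhodamine B assay, tested at 10 uM (a lower number here means less inhibition, a higher number more inhibition at the concentration tested (going by the name of the read-out)), the lowest of the three numbers measured so far. Compound 3 `CC(=O)OC[C@H]1O[C@@H](n2cc(-c3cc(-c4ccccc4)no3)c(=O)[nH]c2=O)C[C@@H]1OC(C)=O` gives 87.6% in this assay, and compound 1 `CC(=O)OC[C@H]1O[C@@H](n2cc(-c3cn(Cc4ccc(C(C)C)cc4)nn3)c(=O)[nH]c2=O)C[C@@H]1OC(C)=O` gives 95.4%. The unmeasured compound 4 `CCc1ccc(-c2cc(-c3cn([C@H]4C[C@H](OC(C)=O)[C@@H](COC(C)=O)O4)c(=O)[nH]c3=O)on2)cc1` differs from compound 2 in one place: ethyl in place of tert-butyl on an aromatic carbon. Within the data shown here, the only measured step that bears on this change is the one from compound 2 to compound 3, where hydrogen replaces tert-butyl on the same aromatic carbon and the number rises by a number 54.8 percentage points higher from compound 2 to compound 3 (beyond the scatter), well beyond the scatter. Since ethyl is smaller than tert-butyl but larger than hydrogen, a rise of a number 37.2 percentage points higher from compound 2 to compound 4 (beyond the scatter) is expected, smaller than that step. Compound 4 is therefore estimated at 70%, with a range from 40% to 95%.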

Compound 4, a percentage reported as inhibition, at one concentration (the size of the read-out at that concentration, not a potency): 72.6%
Estimate against measurement, compound 4: 2.6 percentage points below; low and high end bracket the measured number.
By their numbers in this assay, from the lowest: compound 2; then compound 4; then compounds 3 and 1 (each within the scatter of the next).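

In this assay, ethyl gives an intermediate result at this aromatic carbon: replacing tert-butyl with it gives a number 39.8 percentage points higher from compound 2 to compound 4 (beyond the scatter), while replacing hydrogen with it gives a number 15 percentage points lower from compound 3 to compound 4 (beyond the scatter). The number therefore falls in two stages across hydrogen, ethyl and tert-butyl, so the drop is not confined to tert-butyl. No measurement shown gives a reason for this trend.

Going by these compounds, what a straight butyl chain or an amine would do at this carbon remains open, so the roles of chain length and branching cannot yet be separated.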